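Adding a methoxy group to the benzyl ring of compound 3

The source may hold more compounds than are shown below. What is called first, only, known or untested is meant among the compounds shown, and "the series" means these compounds.

Compound 3 `O=S(=O)(NCCCNCc1ccccc1)c1cc(C(F)(F)F)cc(C(F)(F)F)c1` gives 13000 nM in a functional assay on ASPC1 cells (Homo sapiens) for inhibition, read by MTT assay, with a stated time of 72 h (a lower number here means a stronger inhibitor of growth, a higher number a weaker inhibitor of growth), the highest number among the three measured compounds. Compound 2 `COc1ccc(CNCCCNS(=O)(=O)c2cc(C(F)(F)F)cc(C(F)(F)F)c2)cc1OC` gives 6400 nM, and compound 1 `O=S(=O)(NCCCCNCc1ccc(Br)cc1)c1cc(C(F)(F)F)cc(C(F)(F)F)c1` gives 2900 nM. Compound 4 `COc1ccc(CNCCCNS(=O)(=O)c2cc(C(F)(F)F)cc(C(F)(F)F)c2)cc1` differs from compound 3 by methoxy in place of hydrogen on an aromatic carbon, on an aromatic carbon of a six-membered aromatic ring of carbon only, para to a large group.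

Within the data shown here, two measured steps bear on this change. The step of a 4.5-fold higher number from compound 1 to compound 3 (0.65 log units; beyond the scatter) removes a para substituent on the benzyl ring together with a chain carbon, so it speaks only in part. The step of a 2.0-fold higher number from compound 2 to compound 3 (0.31 log units; beyond the scatter) removes two methoxy groups from the same ring, one of which is the group that enters in compound 4. Compound 4 therefore sits between compound 2 and compound 3, and a modest lowering of the number is expected.

For compound 4 the expected value in this assay is 8500 nM, with a range from 4000 nM to 18000 nM, an expected step of a 1.5-fold lower number from compound 3 to compound 4 (0.18 log units; within the scatter).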

Compound 4, concentration for 50% growth inhibition: 2800 nM
Beside the measured number, compound 4's estimate is 3.0-fold (0.48 log units) above it; measured number below the stated range.
By their numbers in this assay, from the lowest: compounds 4 and 1 (each within the scatter of the next); then compound 2; then compound 3.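

In this assay, a single methoxy on the aromatic carbon para to a large group carries a clear step on its own, a 4.6-fold lower number from compound 3 to compound 4 (0.67 log units; beyond the scatter). The earlier step with two methoxy groups could not show this, and a 2.3-fold lower number from compound 2 to compound 4 (0.36 log units; beyond the scatter) now shows that the dimethoxy pattern gives a higher number than the single methoxy, so the two groups do not simply add. The third step, a 1.0-fold lower number from compound 1 to compound 4 (0.02 log units; within the scatter), places compound 4 within the scatter of compound 1, even though the two differ in both ring group and chain.

Nothing available here explains the size of these steps. As far as these compounds go, it remains open whether a hydroxyl, an ethoxy or a chlorine on that aromatic carbon would serve as well, and whether a bromine on the chain of compound 4 would separate the ring group's contribution from that of the extra chain carbon in compound 1.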